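This account rests on a few compounds, and the source may have more. Where it says the series, first, only, none or still open, it means among the compounds named here.

Compound 1 `O=C(CCCCC1CCSS1)NCc1cn(CCCOc2ccc3ccc(=O)oc3c2)nn1` gives 42.2% in a functional assay on PC-12 cells (Rattus norvegicus) for cytotoxicity, read by MTT assay, with stated times of 3 h and 2 h, tested at 20 uM; on this read-out lower numbers stand for a weaker effect and higher numbers for a stronger effect at the one concentration tested.
Compound 2 `CC(=O)c1cc2ccc(OCCCn3cc(CNC(=O)CCCCC4CCSS4)nn3)cc2oc1=O` gives 39.8%.
Compound 3 `O=C(CCCCC1CCSS1)NCc1cn(CCCOc2ccc3cc(-c4ccccc4)c(=O)oc3c2)nn1` gives 27.2%.

Compound 3 stands lowest of the three: a number 15 percentage points lower from compound 1 to compound 3 (beyond the scatter) and a number 12.6 percentage points lower from compound 2 to compound 3 (beyond the scatter), both beyond the scatter, whereas a number 2.4 percentage points lower from compound 1 to compound 2 (within the scatter). Compound 4 `O=C(CCCCC1CCSS1)NCc1cn(CCCOc2ccc3cc(-c4ccc(Br)cc4)c(=O)oc3c2)nn1` differs from compound 3 by bromo in place of hydrogen on an aromatic carbon. Among the compounds with values here, none of the measured steps adds a bromo; the two steps that reach compound 3 concern the phenyl itself, so they say nothing about a substituent placed on it. Within the data shown here, with no step of this kind to lean on, the expectation is that the number stays near that of compound 3, giving an estimated a number 0.2 percentage points lower from compound 3 to compound 4 (within the scatter), a change not beyond the scatter. Compound 4 is therefore expected to give about 27%, within a range of 14% to 40%.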

Compound 4, a percentage reported as activity, at one concentration (the size of the read-out at that concentration, not a potency): 69.1%
For compound 4 the middle estimate is 42.1 percentage points below the measured one, and the stated range ends below it.
By their numbers in this assay, from the lowest: compound 3; then compounds 2 and 1 (each within the scatter of the next); then compound 4.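

On the phenyl ring, one bromo changes the picture that the phenyl alone gave: a number 41.9 percentage points higher from compound 3 to compound 4 (beyond the scatter) in this assay, so the lower number seen with phenyl does not carry over to 4-bromophenyl. At the same coumarin-free description of the site, an aromatic carbon of the shared core, 4-bromophenyl also gives a higher number than acetyl or hydrogen: a number 29.3 percentage points higher from compound 2 to compound 4 (beyond the scatter) and a number 26.9 percentage points higher from compound 1 to compound 4 (beyond the scatter). Nothing available explains this rise. On these data alone, whether it is specific to bromo or would also appear with chloro, methoxy or an amine on that ring stays open. So does the effect of bromo elsewhere on the ring.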